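Swapping Methyl for Methoxy in Compound 2

The compounds below may be only part of what the source reports. "The series", "measured", "known", "first", "only" and "open" are said of these compounds alone.

Compound 1 `COC(=O)c1sc2cc(OC)ccc2c1Nc1cc(OC)c(OC)c(OC)c1` gives 10.3 nM
Compound 2 `CCOC(=O)c1sc2cc(C)ccc2c1Nc1cc(OC)c(OC)c(OC)c1` gives 1.5 nM

In a functional assay on SEM cells (Homo sapiens) for cytotoxicity, read by MTT assay, with a stated time of 72 h (a lower number here means a stronger inhibitor, a higher number a weaker inhibitor), compound 2 has the lower of the two numbers, at 1.5 nM, and compound 1 reads 10.3 nM, a gap beyond the usual scatter. For the measured compounds named here, the two compounds differ in more than one place, so no measured step isolates a single change.

Compound 3 `CCOC(=O)c1sc2cc(OC)ccc2c1Nc1cc(OC)c(OC)c(OC)c1` has methoxy in place of the methyl of compound 2, on an aromatic carbon of a six-membered aromatic ring of carbon only (methoxy in place of methyl on an aromatic carbon). Its value in this assay is not yet known. Compound 1 also carries methoxy there and reads 10.3 nM, so a moderately higher number is expected for compound 3, meaning a weaker inhibitor, though probably not by much beyond the scatter. Going by the values given here, no measured pair tests this swap alone, so the expectation remains loose. The expected change is a 2.7-fold higher number from compound 2 to compound 3 (0.43 log units; beyond the scatter) in this estimate. For compound 3 the estimated value is 4 nM, with an expected range from 1.2 nM to 14 nM.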

Compound 3, half-maximal inhibitory concentration: 10.2 nM
Beside the measured number, compound 3's estimate is 2.6-fold (0.41 log units) below it, and the stated range covers the measured number.
By their numbers in this assay, from the lowest: compound 2; then compounds 3 and 1 (each within the scatter of the next).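

In this assay the swap of methoxy in place of methyl on an aromatic carbon of the six-membered ring now stands as a single measured change, and it gives a 6.8-fold higher number from compound 2 to compound 3 (0.83 log units; beyond the scatter) in this series, a step beyond the scatter that marks this ring position as one where the assay responds to the group present. The other single change, methyl in place of hydrogen on a saturated chain carbon bound to an oxygen next to a carbonyl group, gives a 1.0-fold lower number from compound 1 to compound 3 (0.00 log units; within the scatter) with methoxy on the ring, so with that group in place this chain change shows no step beyond the scatter. Nothing measured here offers a reason for either step.

The compounds shown leave open whether the chain change would read the same with methyl on the ring, since it is tested only with methoxy there. They also leave open how an amine, a chlorine or a longer ethoxy group would read on this aromatic carbon, and whether the number follows the size of the group at all.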